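Triazolyl in place of cyanomethylpyrazolyl on the shared core

The source may report more compounds than this note shows. Statements on the series, on what has been measured and on what is new or still open speak of the compounds shown alone.

Measured compounds in this series:
compound 1 `Cc1ccc(CNC(=O)c2cccc(C(C)Oc3cccnc3Nc3ncccn3)c2)cc1`; in a functional assay on NCI-H3122 cells (Homo sapiens) for antiproliferative activity, read by MTT assay, with a stated time of 48 h (on this read-out higher numbers stand for weaker inhibition and lower numbers for stronger inhibition), compound 1 gives > 100000 nM, which is a limit of the assay and not a number.
compound 2 `Cc1ccc(CNC(=O)c2cccc(C(C)Oc3cccnc3Nc3cnn(CC#N)c3)c2)cc1`; in this assay compound 2 gives 38400 nM.

Within the data shown here, compound 2 thus holds the only number given in this assay; the other value is a limit. Among the measured compounds shown here, the one step measured, an at least 2.6-fold lower number from compound 1 to compound 2 (0.41 log units; beyond the scatter), is read against the limit of > 100000 nM in this assay, at which 1 of the 2 values shown sits, and shows only that changing the group on the nitrogen on the aromatic ring moves the read-out, without saying how far a third group will sit.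

Compound 3 `Cc1ccc(CNC(=O)c2cccc(C(C)Oc3cccnc3Nn3cnnc3)c2)cc1` differs from compound 2 in the same place: 4H-1,2,4-triazol-4-yl in place of 1-(cyanomethyl)-1H-pyrazol-4-yl on a nitrogen on an aromatic ring. The step from compound 1 to compound 2 is the only one that bears on it, and compound 3 carries neither of those two groups. The expectation is therefore a number near that of compound 2, more likely somewhat higher than lower, with a fair chance of a limit again; the expected step is a 1.6-fold higher number from compound 2 to compound 3 (0.19 log units; within the scatter). For compound 3 the estimate in this assay is 60000 nM, expected to fall between 15000 nM and 150000 nM.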

Compound 3, half-maximal inhibitory concentration: 23700 nM
The estimate for compound 3 lay 2.5-fold (0.40 log units) above the measured number; measured number inside the range.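

In this assay, replacing the cyanomethylpyrazolyl group with the triazolyl group gives a change within the scatter (a 1.6-fold lower number from compound 2 to compound 3 (0.21 log units; within the scatter)), so the 8 heavy atoms of 1-(cyanomethyl)-1H-pyrazol-4-yl and the 5 heavy atoms of 4H-1,2,4-triazol-4-yl on this nitrogen give read-outs that cannot be told apart. The triple bond that leaves with the cyanomethyl chain is therefore not needed for a measurable number on the shared core, which compound 2 alone could not show. The second step away from pyrimidin-2-yl (an at least 4.2-fold lower number from compound 1 to compound 3 (0.62 log units; beyond the scatter)) starts from the limit of compound 1, so its true size stays open: the limit of > 100000 nM in this assay, at which 1 of the 3 values shown sits.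

From the compounds shown here alone, with only these three groups, it remains open whether a plain phenyl ring, a methyl-substituted triazole or a simple amine on this nitrogen would move the read-out beyond the scatter of compound 2 and compound 3. Going by these compounds, it is also open whether the same order of groups would hold if the 4-methylbenzyl amide on the shared core gave way to a carboxylic acid or a longer chain.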